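The source may report more compounds than this note shows. Statements on the series, on what has been measured and on what is new or still open speak of the compounds shown alone.

Compound 3 `CCn1cc(C(=O)Nc2cccc([N+](=O)[O-])c2)c(=O)c2cc(F)c(N3CCNC(C)C3)c(F)c21` gives the lowest number of the three in a functional assay on KB cells (Homo sapiens) for cytotoxicity, read by MTT assay (on this read-out lower numbers stand for stronger inhibition and higher numbers for weaker inhibition), with 1700 nM. Compound 2 `CCn1cc(C(=O)Nc2ccccc2N)c(=O)c2cc(F)c(N3CCNC(C)C3)c(F)c21`, with 2800 nM, sits within the scatter of it, while compound 1 `CCn1cc(C(=O)Nc2ccccc2)c(=O)c2cc(F)c(N3CCNC(C)C3)c(F)c21`, with 4400 nM, lies beyond it, as a 2.6-fold lower number from compound 1 to compound 3 (0.41 log units; beyond the scatter) shows. Compound 4 `CCn1cc(C(=O)Nc2cc([N+](=O)[O-])ccc2F)c(=O)c2cc(F)c(N3CCNC(C)C3)c(F)c21` differs from compound 3 by fluoro in place of hydrogen on an aromatic carbon. Going by the values given here, the measured steps that bear on this are the two that place a group on the same ring, a 1.6-fold lower number from compound 1 to compound 2 (0.20 log units; within the scatter) and a 2.6-fold lower number from compound 1 to compound 3 (0.41 log units; beyond the scatter); a fluoro on this ring has no precedent among the measured compounds. The first of those steps was within the scatter and the second only modest, so in this assay no step beyond the scatter is expected, with a 1.1-fold lower number from compound 3 to compound 4 (0.05 log units; within the scatter). Compound 4 is therefore estimated at 1500 nM, between 600 nM and 4000 nM.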

Compound 4, half-maximal inhibitory concentration: 3200 nM
Compound 4: middle estimate off by 2.1-fold (0.33 log units), on the low side; the range from low to high includes it.
By their numbers in this assay, from the lowest: compounds 3, 2, 4 and 1 (each within the scatter of the next, the first and the last beyond it).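

In this assay, fluoro on the 3-nitrophenyl ring, ortho to a large group and para to a nitro group, gives a 1.9-fold higher number from compound 3 to compound 4 (0.27 log units; within the scatter), so this first fluoro on that ring does not move the number past the scatter. The 2-fluoro-5-nitrophenyl group also stays within the scatter of both 2-aminophenyl, a 1.1-fold higher number from compound 2 to compound 4 (0.06 log units; within the scatter), and plain phenyl, a 1.4-fold lower number from compound 1 to compound 4 (0.14 log units; within the scatter), although the 3-nitrophenyl group alone stood beyond the scatter of phenyl. No evidence bearing on this result is available. The compounds shown leave open whether chloro or methoxy at this place would read differently, and what fluoro does on a ring without the nitro group.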